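This account rests on a few compounds, and the source may have more. Where it says the series, first, only, none or still open, it means among the compounds named here.

Measured so far:
- compound 1 `Cc1ccc(C23CCC(=O)N2CCCO3)c(C)c1`: < 50 mg/kg
- compound 2 `COc1ccc(C(=O)CCC(=O)NCCCO)cc1`: 150 mg/kg
- compound 3 `O=C1CCC2(c3ccccc3)OCCCN12`: 37.5 mg/kg

Of the compounds shown here, three have been tested in a functional assay on the whole organism (Central nervous system) for activation, with Mus musculus as the target; on this read-out lower numbers stand for an effect already at smaller amounts and higher numbers for an effect only at larger amounts of compound. Compound 1 `Cc1ccc(C23CCC(=O)N2CCCO3)c(C)c1` gives only a limit of the assay and not a number, < 50 mg/kg (the limit of < 50 mg/kg in this assay, at which 1 of the 3 values shown sits). Among the two numbers, compound 2 `COc1ccc(C(=O)CCC(=O)NCCCO)cc1` stands highest with 150 mg/kg. Compound 3 `O=C1CCC2(c3ccccc3)OCCCN12` gives 37.5 mg/kg, and the gap between compound 3 and compound 2 is beyond the usual scatter of this assay.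

Compound 4 `O=C(CCC(=O)c1ccc(Cl)cc1)NCCCO` has not yet been measured. It differs from compound 2 in one place: chloro in place of methoxy on an aromatic carbon. For the measured compounds named here, no step between two measured compounds has been recorded, so there is nothing among the measured compounds to show how large a change of this kind tends to be in this assay. The expectation is therefore a step from compound 2 to compound 4 of no change at the digits printed from compound 2 to compound 4 (within the scatter), within the scatter in either direction. For compound 4 the estimate in this assay is 150 mg/kg, with a range from 75 mg/kg to 300 mg/kg.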

Compound 4, dose for half-maximal effect: 300 mg/kg
For compound 4 the middle estimate is 2.0-fold (0.30 log units) below the measured one, within the range that was stated.
By their numbers in this assay, from the lowest: compound 3; then compounds 2 and 4 (each within the scatter of the next).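

Chloro in place of methoxy on an aromatic carbon, para to a large group, gives a 2.0-fold higher number from compound 2 to compound 4 (0.30 log units; within the scatter) in this assay, and this is the first step between two measured compounds in the set. At this position, the two groups therefore cannot be told apart on this read-out, even though the methoxy is counted with a hydrogen-bond acceptor and the chloro with none. Nothing measured here bears on why this change stays within the scatter.

One swap at one position cannot show whether a very different group, such as an amine or a carboxylic acid on the same aromatic carbon, would also leave the number within the scatter. It also leaves open whether chloro in place of methoxy would give a similar step on the core of compound 3.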